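A pyridin-2-yl amide on the shared core

A few compounds are considered here, and "the series" means these few. Any claim that something is new, unique, unknown or untested is made for them only; others in the source may bear on it.

Compound 1: `O=C(COc1ccc(/C=C2\SC(=O)NC2=O)cc1)Nc1nc2ccccc2s1`, in a functional assay on K562 cells (Homo sapiens) for cytotoxicity, read by sulforhodamine B assay, with a stated time of 48 h (a lower number here means a stronger inhibitor of growth, a higher number a weaker inhibitor of growth), compound 1 gives < 100000 nM.
Compound 2: `O=C(COc1ccc(/C=C2\SC(=O)NC2=O)cc1)Nc1ncc([N+](=O)[O-])s1`, in this assay compound 2 gives < 100000 nM.
Compound 3: `O=C(COc1ccc(/C=C2\SC(=O)NC2=O)cc1)Nc1ccccn1`, not yet measured.

The value for compound 1 is a limit of the assay, not a number. The value for compound 2 is likewise a limit. The step that the two limits leave unreadable from compound 1 to compound 2 cannot be read from two limits, and compound 2 stands only at the limit of < 100000 nM in this assay, at which 2 of the 2 values shown sit, the point where both measured values sit. Compound 3 differs from compound 2 by pyridin-2-yl in place of 5-nitro-1,3-thiazol-2-yl on an amide-type nitrogen. Among the compounds with values here, no measured step bears on this change in a readable way, since the only recorded step, from compound 1 to compound 2, is unreadable and neither value is a number. The expectation for compound 3 rests on the shared limit alone, so no step beyond the scatter is expected in either direction, and the estimated step that the limit leaves unreadable from compound 2 to compound 3 is set near zero. Compound 3 is expected to give about 30000 nM, with a range from 5000 nM to 100000 nM, and a fair chance remains that this assay again reports only a limit.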

Compound 3, concentration for 50% growth inhibition: < 100000 nM
Compound 3 was reported as a limit; the forecaster's own chance of this, stated with the estimate: 50%; the middle value is on the limit's open side.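

In this assay compound 3 gives < 100000 nM and this is a limit of the assay, not a number. No step among compound 1, compound 2 and compound 3 can be read, since all three values are limits: the limit of < 100000 nM in this assay, at which 3 of the 3 values shown sit.

The compounds shown leave open how strongly each inhibits growth and whether exchanging the group on the amide nitrogen changes that at all.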